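Removing the para chloro from the hydrazone of compound 2

The compounds below may be only part of what the source reports. "The series", "measured", "known", "first", "only" and "open" are said of these compounds alone.

Measured so far:
compound 1 `COc1ccc(OC)c(/C=C/c2nnc(Nc3ccc(Cl)cc3)o2)c1` — in a functional assay on OVCAR-5 cells (Homo sapiens) for antiproliferative activity, read by sulforhodamine B assay, with a stated time of 48 h (a higher number here means a weaker inhibitor of growth, a lower number a stronger inhibitor of growth), compound 1 gives > 100000 nM, a limit of the assay rather than a number.
compound 2 `COc1ccc(OC)c(/C=C/C(=O)N/N=C/c2ccc(Cl)cc2)c1` — in this assay compound 2 gives > 100000 nM, again a limit and not a number.

Compound 2 therefore stands at the limit of > 100000 nM in this assay, at which 2 of the 2 values shown sit; no finite growth-inhibition value exists for it, and nothing within the shown data separates it from compound 1. Within the data shown here, no step between two measured compounds is available, so no measured size of change can be quoted.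

Compound 3 `COc1ccc(OC)c(/C=C/C(=O)N/N=C/c2ccccc2)c1` differs from compound 2 by hydrogen in place of chloro on an aromatic carbon. The expectation for this step in this assay is no change beyond the scatter, so the step from compound 2 to compound 3 is estimated as a number no higher from compound 2 to compound 3 (the limit leaves the size open). Compound 3 is accordingly expected to sit near 100000 nM, within 30000 nM to 300000 nM, most probably reported as a limit once more.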

Compound 3, concentration for total growth inhibition: > 100000 nM
Compound 3 was reported as a limit (the forecaster's own chance of this, stated with the estimate: 85%); the middle value lies on the limit itself.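

The step between compound 2 and compound 3 cannot be read, with both reported as limits rather than numbers: the limit of > 100000 nM in this assay, at which 3 of the 3 values shown sit.

From the compounds shown here alone, whether hydrogen in place of chloro on the aromatic carbon changes growth inhibition in this assay stays open, as does where any compound of this series would give a finite value.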